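Chloro to methoxy, repeated on a second core

The source may report more compounds than this note shows. Statements on the series, on what has been measured and on what is new or still open speak of the compounds shown alone.

Compound 1 `COc1cc2ncnc(Nc3cccc(Cl)c3)c2cc1OCCCN1CCNCCNCCNCC1`: 1420 nM
Compound 2 `COc1cccc(Nc2ncnc3cc(OC)c(OCCCN4CCNCCNCCNCC4)cc23)c1`: 3210 nM
Compound 3 `COc1cc2ncnc(Nc3cccc(Cl)c3)c2cc1OCCCN1CCNCCNCC1`: 1130 nM

All three compounds were tested in a functional assay on A-431 cells (Homo sapiens) for antiproliferative activity, read by MTT assay, with a stated time of 72 h; a higher number here means a weaker inhibitor, a lower number a stronger inhibitor. Compound 1 and compound 3 differ only in the ring at the end of the chain: a group of 9 heavy atoms (6 carbon, 3 nitrogen; one nine-membered non-aromatic ring with 3 hetero atoms) in place of a group of 12 heavy atoms (8 carbon, 4 nitrogen; one twelve-membered non-aromatic ring with 4 hetero atoms), on a saturated chain carbon, three bonds along the chain from an oxygen on an aromatic ring. This exchange of cores moved the read-out little, as seen in a 1.3-fold lower number from compound 1 to compound 3 (0.10 log units; within the scatter). Compound 2 differs from compound 1 in a single place: methoxy in place of chloro on an aromatic carbon. That change gave a higher number, a 2.3-fold higher number from compound 1 to compound 2 (0.35 log units; beyond the scatter).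

Compound 4 `COc1cccc(Nc2ncnc3cc(OC)c(OCCCN4CCNCCNCC4)cc23)c1` has not yet been measured. It carries the core of compound 3 with the same change applied: methoxy in place of chloro on an aromatic carbon. The place of the change is described in the same words in both pairs, so this is the same change made on a second core. Since the two cores gave values within the scatter of each other, a step of similar size to the earlier one is expected from compound 3 to compound 4, namely a 2.3-fold higher number from compound 3 to compound 4 (0.36 log units; beyond the scatter). This expectation rests on a 2.3-fold higher number from compound 1 to compound 2 (0.35 log units; beyond the scatter) together with a 1.3-fold lower number from compound 1 to compound 3 (0.10 log units; within the scatter). In this assay compound 4 is therefore estimated at 2600 nM, with a likely range from 1400 nM to 4800 nM.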

Compound 4, half-maximal inhibitory concentration: 8530 nM
Beside the measured number, compound 4's estimate is 3.3-fold (0.52 log units) below it, outside the stated range (above it).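

In this assay, methoxy in place of chloro gave a 7.5-fold higher number from compound 3 to compound 4 (0.88 log units; beyond the scatter), so the change did not carry over from one core to the other at a constant size: the same change on two cores in this assay, a 2.3-fold higher number (0.35 log units; beyond the scatter) from compound 1 to compound 2 and a 7.5-fold higher number (0.88 log units; beyond the scatter) from compound 3 to compound 4, 3.3-fold (0.52 log units) apart, beyond the scatter of two such steps

Seen from the other side, the exchange of the ring at the end of the chain moved the read-out little with chloro but gave a 2.7-fold higher number from compound 2 to compound 4 (0.42 log units; beyond the scatter) with methoxy, so the effects of the two places do not simply add: the same change on two cores in this assay, a 1.3-fold lower number (0.10 log units; within the scatter) from compound 1 to compound 3 and a 2.7-fold higher number (0.42 log units; beyond the scatter) from compound 2 to compound 4, 3.3-fold (0.52 log units) apart, beyond the scatter of two such steps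

The direction of the chloro to methoxy step was the same on both cores, but this rests on a single pair of cores and one exchange, and it does not show why the steps differ in size or how the change would behave on any other core.

From the compounds shown here alone, it remains open whether the wider step on the core of compound 3 also appears with other groups at this place, such as fluoro, methyl or hydroxy. Also open, going by these compounds, is whether a shorter or longer chain to the ring would alter the gap between the two steps.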